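A Chloro Group Added to Compound 2

The source may hold more compounds than are shown below. What is called first, only, known or untested is meant among the compounds shown, and "the series" means these compounds.

Measured in a functional assay on OVCAR-4 cells (Homo sapiens) for inhibition, read by sulforhodamine B assay, with a stated time of 48 h; a higher number here means a weaker inhibitor of growth, a lower number a stronger inhibitor of growth:
Compound 1 `COc1cc(-c2nn(-c3cccc(NC(=O)Nc4cc(C(F)(F)F)cc(C(F)(F)F)c4)c3)cc2-c2ccncc2)ccc1Cl`: 9640 nM
Compound 2 `COc1cc(-c2nn(-c3cccc(NC(=O)c4cccc(C(F)(F)F)c4)c3)cc2-c2ccncc2)ccc1Cl`: > 50000 nM

On these data alone, the value of compound 2, > 50000 nM, is a limit of this assay and not a number, so its true position is unknown. Compound 3 `COc1cc(-c2nn(-c3cccc(NC(=O)c4ccc(Cl)c(C(F)(F)F)c4)c3)cc2-c2ccncc2)ccc1Cl` has chloro in place of hydrogen on an aromatic carbon, turning 3-(trifluoromethyl)phenyl into 4-chloro-3-(trifluoromethyl)phenyl (chloro in place of hydrogen on an aromatic carbon). Going by the values given here, no measured step shows what this change does. A modest shift toward stronger inhibition is expected, though the result may remain at the limit. The expected step is estimated to be an at least 1.6-fold lower number from compound 2 to compound 3 (0.22 log units; that floor lies within the scatter). Compound 3 is estimated at 30000 nM, with an expected range from 10000 nM to 50000 nM.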

Compound 3, concentration for total growth inhibition: > 32500 nM
Compound 3 gave a limit, no number (the forecaster's own chance of this, stated with the estimate: 45%); at least 1.0-fold (0.03 log units) between middle value and limit.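

Compound 2 and compound 3 each gave a limit and not a number, and no step can be read between them. On these data alone, whether the added chloro changes growth inhibition at all stays open.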